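This account rests on a few compounds, and the source may have more. Where it says the series, first, only, none or still open, it means among the compounds named here.

Compound 3 `Oc1cccc(-c2cc(-c3ccc(Cl)cc3)nc(-c3ccsc3)c2)c1` is one of three close analogues that differ only in the aromatic group placed on the shared core. In a functional assay on DU-145 cells (Homo sapiens) for cytotoxicity, read by CCK-8 assay and cell counting, with a stated time of 2 days (a lower number here means a stronger inhibitor, a higher number a weaker inhibitor), compound 3 gives 11600 nM. Compound 1 `Oc1cccc(-c2cc(-c3ccc(Cl)cc3)nc(-c3cccs3)c2)c1` gives 11600 nM, and compound 2 `Oc1cccc(-c2cc(-c3ccc(Cl)cc3)nc(-c3cccnc3)c2)c1` gives 26800 nM. The step of no change at the digits printed from compound 1 to compound 3 (within the scatter) shows that swapping thiophen-2-yl for thiophen-3-yl leaves the number untouched, so compound 3 stands level with compound 1, and together they give the lowest numbers of the three. The step of a 2.3-fold lower number from compound 2 to compound 3 (0.36 log units; beyond the scatter) shows that the pyridin-3-yl analogue sits above both, as does a 2.3-fold higher number from compound 1 to compound 2 (0.36 log units; beyond the scatter).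

Compound 4 `Oc1cccc(-c2cc(-c3ccc(Cl)cc3)nc(-c3ccccn3)c2)c1` carries the change (pyridin-2-yl in place of thiophen-3-yl on an aromatic carbon). For the measured compounds named here, the step that bears on it most is a 2.3-fold lower number from compound 2 to compound 3 (0.36 log units; beyond the scatter), since pyridine again replaces thiophene, though at a different ring position, and there is no measured step that separates the two pyridine isomers. A modest rise is therefore expected, a 1.7-fold higher number from compound 3 to compound 4 (0.24 log units; within the scatter). Compound 4 is estimated at 20000 nM in this assay, with a range from 9000 nM to 45000 nM.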

Compound 4, half-maximal inhibitory concentration: 8090 nM
For compound 4 the middle estimate is 2.5-fold (0.39 log units) above the measured one; the measured number lies below the stated range.
By their numbers in this assay, from the lowest: compounds 4, 1 and 3 (each within the scatter of the next); then compound 2.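

For the compounds shown here, the two pyridine isomers now separate in this assay at this position, next to the ring nitrogen of the shared core, with a 3.3-fold lower number from compound 2 to compound 4 (0.52 log units; beyond the scatter) as the only new step beyond the scatter. Pyridine in place of thiophene therefore does not raise the number in itself, since the steps of a 1.4-fold lower number from compound 3 to compound 4 (0.16 log units; within the scatter) and a 1.4-fold lower number from compound 1 to compound 4 (0.16 log units; within the scatter) leave pyridin-2-yl level with both thiophene analogues, and compound 2 alone stands apart among the four. No measurement shown here accounts for the difference between the two pyridine isomers.

From the compounds shown here alone, it remains open whether pyridin-4-yl, or a phenyl ring carrying an amine or a carboxylic acid, would stay level with this group. Going by these compounds, it is also open whether the gap between the pyridine isomers would persist if the 3-hydroxyphenyl or 4-chlorophenyl group were changed.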